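A few compounds are considered here, and "the series" means these few. Any claim that something is new, unique, unknown or untested is made for them only; others in the source may bear on it.

Compound 2 `COc1ccc(F)c(-c2ncc(COc3cccc([C@@H](CC(=O)O)C4CC4)c3)nc2C=C(C)C)c1`: 9.4 nM
Compound 1 `COc1ccc(F)c(-c2ncc(COc3cccc([C@@H](CC(=O)O)C4CC4)c3)nc2C2=CCCC2(C)C)c1`: 37 nM

In a functional assay on HEK293 cells for agonist activity at Free fatty acid receptor 1 (Homo sapiens), read by fluorescence and calcium flux, with a stated time of 1 h (on this read-out lower numbers stand for an effect already at smaller amounts and higher numbers for an effect only at larger amounts of compound), compound 2 stands lowest of the two numbers, separated from compound 1 by a 3.9-fold lower number from compound 1 to compound 2 (0.60 log units; beyond the scatter). Compound 3 `COc1ccc(F)c(-c2ncc(COc3cccc([C@@H](CC(=O)O)C4CC4)c3)nc2N2CC3(CCC3)C2)c1` differs from compound 2 by a group of 7 heavy atoms (6 carbon, 1 nitrogen; one four-membered non-aromatic ring of carbon only, one four-membered non-aromatic ring with 1 hetero atom) in place of a group of 4 heavy atoms (4 carbon; no ring), on an aromatic carbon. For the measured compounds named here, the only measured step, from compound 1 to compound 2, altered the same aromatic carbon of the shared core and moved the number modestly, so this position does respond to its substituent. Going by the values given here, the new group resembles neither of those already seen, and no measured step bears on it directly. Compound 3 is therefore expected to give a somewhat higher number, a step of a 2.1-fold higher number from compound 2 to compound 3 (0.33 log units; beyond the scatter), estimated at 20 nM with a range from 5 nM to 80 nM.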

Compound 3, half-maximal effective concentration: 4.5 nM
For compound 3 the middle estimate is 4.4-fold (0.65 log units) above the measured one; the whole stated range lies above it.
By their numbers in this assay, from the lowest: compound 3; then compound 2; then compound 1.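

At this aromatic carbon, the group with two four-membered rings, joined through its nitrogen, gives in this assay a 2.1-fold lower number from compound 2 to compound 3 (0.32 log units; beyond the scatter) and also an 8.2-fold lower number from compound 1 to compound 3 (0.91 log units; beyond the scatter). For the compounds shown here, the position therefore accepts a group joined through nitrogen as well as the two joined through carbon, and a group of 7 heavy atoms need not raise the number above that of 2-methylprop-1-en-1-yl, although the one in compound 1 does. Nothing measured here explains why. As far as these compounds go, whether a diethylamino group, which has no ring, would match compound 3 remains open.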